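Adding a nitro group to compound 3

The compounds below may be only part of what the source reports. "The series", "measured", "known", "first", "only" and "open" are said of these compounds alone.

Measured in a functional assay on NCI-H460 cells (Homo sapiens) for inhibition, read by MTT assay, with a stated time of 24 h, tested at 1 ug/mL; on this read-out lower numbers stand for less inhibition of growth and higher numbers for more inhibition of growth at the one concentration tested:
Compound 1 `O=C(CCCCC1CCSS1)Nc1ccc([N+](=O)[O-])c(C(F)(F)F)c1`: 19.1%
Compound 2 `O=C(CCCCC(S)CCS)Nc1cccc(Cl)c1`: 7.2%
Compound 3 `O=C(CCCCC(S)CCS)Nc1cccc(C(F)(F)F)c1`: 8.26%

Compound 3 lies within the scatter of compound 2, while compound 1 reads higher than compound 3 by more than the scatter. The next compound is compound 4 `O=C(CCCCC(S)CCS)Nc1ccc([N+](=O)[O-])c(C(F)(F)F)c1`, and its change from compound 3 is nitro in place of hydrogen on an aromatic carbon, ortho to a trifluoromethyl group. Among the compounds with values here, the only measured step, a number 1.1 percentage points higher from compound 2 to compound 3 (within the scatter), involves no nitro and offers little guidance. Compound 1 carries the same nitro group on a different chain end and gives 19.1%, so a modest rise in this assay is expected. The expected change is a number 4.7 percentage points higher from compound 3 to compound 4 (within the scatter). For compound 4 the estimate is 13%, with an expected range from 3% to 27%.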

Compound 4, percent growth inhibition at one concentration: 6.29%
Compound 4: the middle estimate sits 6.7 percentage points above what was measured, and the stated range covers the measured number.
By their numbers in this assay, from the lowest: compounds 4, 2 and 3 (each within the scatter of the next); then compound 1.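

In this assay, nitro in place of hydrogen on an aromatic carbon, ortho to a trifluoromethyl group, gives a number 2 percentage points lower from compound 3 to compound 4 (within the scatter), so this change at this position does not separate the two compounds. The larger difference lies at the chain end: the group with no ring, in place of the group with a five-membered non-aromatic ring, gives a number 12.8 percentage points lower from compound 1 to compound 4 (beyond the scatter). Nothing measured explains either result. The compounds shown leave open whether an amine or a carboxylic acid at this position would give a step beyond the scatter. They also leave open what nitro does when the chain end is that of compound 1.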